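Hydroxamic acids with a varied benzyl group: from compound 2 to compound 3

The source may hold more compounds than are shown below. What is called first, only, known or untested is meant among the compounds shown, and "the series" means these compounds.

Measured so far:
compound 1, `O=C(/C=C/c1ccc(OCc2nc(C3CCN(Cc4ccccc4F)CC3)no2)cc1)NO`: 68%
compound 2, `O=C(/C=C/c1ccc(OCc2nc(C3CCN(Cc4ccccc4Cl)CC3)no2)cc1)NO`: 59%

Of the compounds shown here, two have been measured in an assay on isolated protein for inhibition of protein deacetylase HDAC6 (Homo sapiens), read by fluorescence, with a stated time of 1 h, tested at 100 nM; a higher number here means more inhibition at the concentration tested (going by the name of the read-out), a lower number less inhibition. Compound 1, `O=C(/C=C/c1ccc(OCc2nc(C3CCN(Cc4ccccc4F)CC3)no2)cc1)NO`, gives 68% in this assay. Compound 2, `O=C(/C=C/c1ccc(OCc2nc(C3CCN(Cc4ccccc4Cl)CC3)no2)cc1)NO`, gives 59% in this assay. Among the measured compounds shown here, the one measured step, a number 9 percentage points lower from compound 1 to compound 2 (within the scatter), concerns chloro in place of fluoro on an aromatic carbon, and it lies within the scatter. On the two numbers at hand compound 2 stands lowest, with compound 1 nearest, and that gap is within the scatter, so no order between the two can be read.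

Compound 3, `COc1ccc(CN2CCC(c3noc(COc4ccc(/C=C/C(=O)NO)cc4)n3)CC2)cc1`, has not yet been measured in this assay. It differs from compound 2 in one place: 4-methoxyphenyl in place of 2-chlorophenyl on a saturated chain carbon bound to an amine nitrogen in a ring. Cut one bond further out, the change reads 2-chlorobenzyl to 4-methoxybenzyl. For the measured compounds named here, no measured step covers this change; the only step on hand, a number 9 percentage points lower from compound 1 to compound 2 (within the scatter), exchanges one halogen for another at the same place and stayed within the scatter. On that basis compound 3 is expected to move by no more than the scatter, which means an expected step of a number 1 percentage points higher from compound 2 to compound 3 (within the scatter). The estimate for compound 3 in this assay is 60%, with a range from 40% to 78%.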

Compound 3, a percentage reported as inhibition, at one concentration (the size of the read-out at that concentration, not a potency): 75%
The estimate for compound 3 lay 15 percentage points below the measured number; low and high end bracket the measured number.
By their numbers in this assay, from the lowest: compounds 2, 1 and 3 (each within the scatter of the next, the first and the last beyond it).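

In this assay, among the compounds shown here, 4-methoxyphenyl in place of 2-chlorophenyl on the saturated chain carbon bound to the amine nitrogen in the ring gives a number 16 percentage points higher from compound 2 to compound 3 (beyond the scatter) and is the first step at this position to go beyond the scatter, showing that the group carried here can shift the read-out in a way the exchange of one halogen for another did not. The same group in place of 2-fluorophenyl gives a number 7 percentage points higher from compound 1 to compound 3 (within the scatter) and stays within the scatter, so the difference is established against the chloro compound only, and no order can be read between the fluoro compound and the methoxy compound. Nothing available here accounts for the step from the chloro compound to the methoxy compound.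

Because 2-chlorobenzyl and 4-methoxybenzyl differ both in the group they carry and in the number in their names, the compounds shown leave open which of the two differences matters. They also leave open how an unsubstituted benzyl group, or a benzyl group carrying a dimethylamino group or a carboxylic acid, would read at this position.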